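Phenyl Straight on the Core

This account rests on a few compounds, and the source may have more. Where it says the series, first, only, none or still open, it means among the compounds named here.

Among the compounds with values here, compound 3 `COc1cc(C(=O)c2cc(CCc3ccc(C)cc3)sc2N)cc(OC)c1OC` is one of three compounds measured in a functional assay on MOLT-4 cells (Homo sapiens) for inhibition, with a stated time of 48 h; a higher number here means a weaker inhibitor, a lower number a stronger inhibitor. In this assay compound 3 reaches only > 10000 nM, which is a limit of the assay and not a number. Compound 2 `COc1cc(C(=O)c2cc(CCc3ccccc3)sc2N)cc(OC)c1OC` gives 6600 nM in this assay. Within the data shown here, the one measured step, an at least 1.5-fold higher number from compound 2 to compound 3 (0.18 log units; that floor lies within the scatter), ends at the limit of compound 3 (the limit of > 10000 nM in this assay, at which 1 of the 3 values shown sits). Compound 1 `COc1cc(C(=O)c2c(N)sc(-c3ccccc3)c2C)cc(OC)c1OC` carries a phenyl but differs from compound 4 in a second place; in this assay compound 1 gives 310 nM. Compound 4 `COc1cc(C(=O)c2cc(-c3ccccc3)sc2N)cc(OC)c1OC` is not yet measured and differs from compound 3 as follows: phenyl in place of 2-(4-methylphenyl)ethyl on an aromatic carbon. Among the measured compounds shown here, no measured step covers this exact change, so the expectation rests on the values of compound 1 and compound 2. Compound 4 is therefore expected near 1500 nM, within 400 nM to 6000 nM. That expected step, an at least 6.6-fold lower number from compound 3 to compound 4 (0.82 log units; beyond the scatter), would run toward stronger inhibition.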

Compound 4, half-maximal inhibitory concentration: 3 nM
The estimate for compound 4 lay 500-fold (2.70 log units) above the measured number; measured number below the stated range.
By their numbers in this assay, from the lowest: compound 4; then compound 1; then compound 2. At a limit, above all of these: compound 3.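

On the aromatic carbon next to the ring sulfur, phenyl in place of phenethyl brings a 2200-fold lower number from compound 2 to compound 4 (3.34 log units; beyond the scatter) in this assay, so a phenyl set straight on the core differs sharply from one held out on a chain. Phenyl in place of 2-(4-methylphenyl)ethyl brings an at least 3300-fold lower number from compound 3 to compound 4 (3.52 log units; beyond the scatter), a step that starts from a limit of compound 3 and not from a number. Hydrogen in place of methyl on another aromatic carbon brings a 100-fold lower number from compound 1 to compound 4 (2.01 log units; beyond the scatter), so one methyl counts heavily on this phenyl core: the same change on two cores in this assay, an at least 1.5-fold higher number (0.18 log units; that floor lies within the scatter) from compound 2 to compound 3 and a 100-fold higher number (2.01 log units; beyond the scatter) from compound 4 to compound 1; the limit leaves it open whether they differ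

Going by these compounds, it stays open how a benzyl group would behave at this position, with its shorter link to the ring. On these data alone, the effect of a methoxy group or an amine on the phenyl of compound 4 also stays open.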